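The source may hold more compounds than are shown below. What is called first, only, known or untested is meant among the compounds shown, and "the series" means these compounds.

Two compounds of this series have been run in a functional assay on MCF7 cells (Homo sapiens) for cytotoxicity, read by MTT assay, with a stated time of 72 h; on this read-out lower numbers stand for stronger inhibition and higher numbers for weaker inhibition. Compound 1 `Cc1cc(=O)n(-c2cccc(F)c2)nc1C(=O)Nc1ccc(Oc2ncnc3ccsc23)cc1` gives 6410 nM in this assay. Going by the values given here, compound 2 `Cc1ccc(-n2nc(C(=O)Nc3ccc(Oc4ncnc5ccsc45)cc3)c(C)cc2=O)cc1` gives 23800 nM in this assay, the higher of the two numbers; the single step, a 3.7-fold higher number from compound 1 to compound 2 (0.57 log units; beyond the scatter), is the only comparison so far. Compound 3 `Cc1ccc(-n2nc(C(=O)Nc3ccc(Oc4ncnc5ccsc45)cc3)c(C)cc2=O)c(C)c1` carries the change methyl in place of hydrogen on an aromatic carbon relative to compound 2. Among the compounds with values here, no measured step adds a methyl to the ring on the aromatic nitrogen; the one step recorded, a 3.7-fold higher number from compound 1 to compound 2 (0.57 log units; beyond the scatter), exchanges that whole ring and so bears only loosely on this change. With nothing directly comparable, the expectation for compound 3 is a step of a 1.0-fold higher number from compound 2 to compound 3 (0.00 log units; within the scatter), that is, no movement beyond the scatter. Compound 3 is therefore estimated at 24000 nM in this assay, within a range from 8000 nM to 70000 nM.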

Compound 3, half-maximal inhibitory concentration: 11900 nM
The estimate for compound 3 lay 2.0-fold (0.30 log units) above the measured number; the range from low to high includes it.
By their numbers in this assay, from the lowest: compounds 1, 3 and 2 (each within the scatter of the next, the first and the last beyond it).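

In this assay, methyl in place of hydrogen on the aromatic carbon ortho to a large group and meta to a methyl group gives a 2.0-fold lower number from compound 2 to compound 3 (0.30 log units; within the scatter) and so shows no step beyond the scatter at this position. Replacing 3-fluorophenyl with 2,4-dimethylphenyl gives a 1.9-fold higher number from compound 1 to compound 3 (0.27 log units; within the scatter) and so, unlike the 4-methylphenyl ring of compound 2, this ring is not separated from the 3-fluorophenyl ring of compound 1 on this read-out. Nothing available explains these numbers.

The compounds shown leave open whether a methoxy group, a chlorine atom or an amine on this same aromatic carbon would give a step beyond the scatter. They also leave open how a 2-methylphenyl ring, lacking the second methyl group, would compare with 2,4-dimethylphenyl.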